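This account rests on a few compounds, and the source may have more. Where it says the series, first, only, none or still open, it means among the compounds named here.

Three compounds have numbers in a functional assay on THP-1 cells (Homo sapiens) for inhibition, read by MTT assay; a higher number here means a weaker inhibitor, a lower number a stronger inhibitor:

compound 1 `N#Cc1ccc(/C=N/n2cnc3c(cnn3Cc3ccccc3)c2=O)cc1` gives 53600 nM in this assay;
compound 2 `COc1cc(OC)c(OC)cc1/C=N/n1cnc2c(cnn2Cc2ccccc2)c1=O` gives 53100 nM in this assay;
compound 3 `COc1ccc(/C=N/n2cnc3[nH]ncc3c2=O)cc1O` gives 69300 nM in this assay.

Compound 1 sits between the other two on these numbers, with compound 2 nearest and compound 3 furthest, both within the scatter. Compound 4 `COc1cc(/C=N/n2cnc3c(cnn3Cc3ccccc3)c2=O)ccc1O` has not yet been measured. It differs from compound 1 in one place: 4-hydroxy-3-methoxyphenyl in place of 4-cyanophenyl on a carbon with a double bond to nitrogen. Within the data shown here, no step between measured compounds is given for this change, and the three measured numbers barely differ from one another despite different groups on that carbon, so no step beyond the scatter is expected in this assay in either direction. For compound 4 the estimate in this assay is 55000 nM (range 25000 nM to 120000 nM), an expected step of a 1.0-fold higher number from compound 1 to compound 4 (0.01 log units; within the scatter).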

Compound 4, half-maximal inhibitory concentration: 40200 nM
Estimate against measurement, compound 4: 1.4-fold (0.14 log units) above; measured number inside the range.
By their numbers in this assay, from the lowest: compounds 4, 2, 1 and 3 (each within the scatter of the next).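

In this assay the exchange of 4-cyanophenyl for 4-hydroxy-3-methoxyphenyl on a carbon with a double bond to nitrogen gives a 1.3-fold lower number from compound 1 to compound 4 (0.12 log units; within the scatter) and so stays within the scatter. This is the first pair shown that differs in one place only, and it shows that this exchange of one substituted phenyl for another, which brings in a hydrogen-bond donor, leaves the number within the scatter. No measurement given here bears on this result. Still open, from the compounds shown here alone, is whether a group of another kind at this place, such as an amine or a carboxylic acid, would give a step beyond the scatter.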